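This account rests on a few compounds, and the source may have more. Where it says the series, first, only, none or still open, it means among the compounds named here.

In a functional assay on thoracic aorta (Rattus norvegicus, strain Wistar), with a stated time of 15 min (a lower number here means that less compound is needed, a higher number that more compound is needed for the effect), compound 1 `Cc1ccc(S(=O)(=O)N(C)C(=O)NC(C)c2cc(C)ccc2OCc2ccccc2)cc1` gives 181000 nM. Compound 2 `Cc1ccc(OCc2ccccc2)c(C(C)NC(=O)N(C)S(=O)(=O)c2ccc(Cl)cc2)c1`, which shares its core, gives 142000 nM. These two values lie within the scatter of each other, so compound 2 stands level with compound 1 and the pair cannot be ranked in this assay.

Compound 3 `Cc1ccc(OCc2ccccc2)c(C(C)NC(=O)N(C)S(=O)(=O)c2ccccc2)c1` is the next to be compared with compound 2. The difference is hydrogen in place of chloro on an aromatic carbon, which turns the 4-chlorophenyl group into phenyl.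

Among the compounds with values here, only one measured step bears on this change, and it concerns the same aromatic carbon: a 1.3-fold lower number from compound 1 to compound 2 (0.11 log units; within the scatter), with chloro in place of methyl. Within the data shown here, that step is small, but no measured compound yet carries hydrogen at this place, so the evidence is indirect. No step beyond the scatter is expected in this assay, and no direction can be favoured with confidence.

The estimated step is a 1.2-fold higher number from compound 2 to compound 3 (0.07 log units; within the scatter), which is expected to stay within the scatter. For compound 3 the expected value is 165000 nM, with an estimated range from 85000 nM to 320000 nM.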

Compound 3, half-maximal effective concentration: 68200 nM
Estimate against measurement, compound 3: 2.4-fold (0.38 log units) above; measured number below the stated range.
By their numbers in this assay, from the lowest: compound 3; then compounds 2 and 1 (each within the scatter of the next).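

In this assay, this aromatic carbon now gives steps beyond the scatter: hydrogen in place of chloro gives a 2.1-fold lower number from compound 2 to compound 3 (0.32 log units; beyond the scatter), and hydrogen in place of methyl gives a 2.7-fold lower number from compound 1 to compound 3 (0.42 log units; beyond the scatter). Both steps are modest, but unlike the earlier exchange of one substituent for the other, they show that this place is not indifferent to change: among these three compounds, the two carrying a substituent here stand level, while compound 3, with phenyl in place of the substituted ring, has the lowest number. Nothing available on these compounds accounts for this difference.

With only chloro, methyl and hydrogen at this place, the compounds shown cannot tell whether any substituent here raises the number or whether the result is particular to these two groups; a fluoro, methoxy, amine or carboxylic acid group on the same carbon would test this. They also leave open whether the lower number seen with phenylsulfonyl would hold if the rest of the shared core were changed, and even compound 3 still needs a high concentration for the effect.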